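Notes on a carbonyl-aryl swap: methoxy to fluorine

The source may report more compounds than this note shows. Statements on the series, on what has been measured and on what is new or still open speak of the compounds shown alone.

Measured so far:
compound 1 `COc1cc(-c2cc(/C=C/C(=O)c3ccc(N)cc3)[nH]n2)cc(OC)c1OC` gives 7020 nM
compound 2 `COc1cc(-c2cc(/C=C/C(=O)c3ccc(Cl)c(Cl)c3)[nH]n2)cc(OC)c1OC` gives > 100000 nM, a limit of the assay
compound 3 `COc1ccc(C(=O)/C=C/c2cc(-c3cc(OC)c(OC)c(OC)c3)n[nH]2)cc1OC` gives 4590 nM

In a functional assay on A549 cells (Homo sapiens) for inhibition, read by sulforhodamine B assay, with a stated time of 48 h (a lower number here means a stronger inhibitor of growth, a higher number a weaker inhibitor of growth), compound 3 stands at the lowest of the two reported numbers, and compound 1 is its nearest neighbour (a 1.5-fold lower number from compound 1 to compound 3 (0.18 log units; within the scatter)). Compound 2 sits only at the limit of this assay (the limit of > 100000 nM in this assay, at which 1 of the 3 values shown sits). Compound 4 `COc1cc(-c2cc(/C=C/C(=O)c3ccc(F)c(F)c3)[nH]n2)cc(OC)c1OC` is not yet measured; it differs from compound 3 by 3,4-difluorophenyl in place of 3,4-dimethoxyphenyl on a carbonyl carbon. The measured step that bears on this is an at least 21-fold lower number from compound 2 to compound 3 (1.33 log units; beyond the scatter), where 3,4-dimethoxyphenyl replaced 3,4-dichlorophenyl; compound 4 now carries 3,4-difluorophenyl in that place, so a large rise in this assay is expected. Compound 4 is therefore estimated at 40000 nM, with a range from 10000 nM to 150000 nM. That estimate corresponds to an expected step of an 8.7-fold higher number from compound 3 to compound 4 (0.94 log units; beyond the scatter).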

Compound 4, concentration for total growth inhibition: 9900 nM
Compound 4: middle estimate off by 4.0-fold (0.61 log units), on the high side; the whole stated range lies above it.
By their numbers in this assay, from the lowest: compounds 3, 1 and 4 (each within the scatter of the next, the first and the last beyond it). At a limit, above all of these: compound 2.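

With 3,4-difluorophenyl on the carbonyl carbon, growth inhibition is largely retained, with a 2.2-fold higher number from compound 3 to compound 4 (0.33 log units; beyond the scatter) and a 1.4-fold higher number from compound 1 to compound 4 (0.15 log units; within the scatter), so a halogenated aryl group at this position is not in itself incompatible with activity. The dichlorophenyl result therefore does not extend to all dihalogenated aryl groups: an at least 10-fold lower number from compound 2 to compound 4 (1.00 log units; beyond the scatter). The value of compound 2 is a limit, so the true size of that step remains unknown: the limit of > 100000 nM in this assay, at which 1 of the 4 values shown sits.

Open, from the compounds shown here alone, is whether a single fluorine suffices here, and how a trifluoromethyl group, a nitrile or a carboxylic acid on this aryl ring would behave.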